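The source may hold more compounds than are shown below. What is called first, only, known or untested is meant among the compounds shown, and "the series" means these compounds.

Measured in a functional assay on K562 cells (Homo sapiens) for inhibition, read by MTT assay, with a stated time of 72 h; a higher number here means a weaker inhibitor of growth, a lower number a stronger inhibitor of growth:
- compound 1 `Nc1n[nH]c2cccc(C#Cc3cccc(NC(=O)c4cccc(C(F)(F)F)c4)c3)c12`: 1540 nM
- compound 2 `Nc1n[nH]c2cccc(C#Cc3cccc(NC(=O)c4cc(C(F)(F)F)cc(C(F)(F)F)c4)c3)c12`: > 10000 nM, a limit of the assay
- compound 3 `Nc1n[nH]c2cccc(C#Cc3cccc(NC(=O)c4cc(F)cc(C(F)(F)F)c4)c3)c12`: 2140 nM

Only compound 1 and compound 3 have actual numbers, and these lie within the scatter of each other. Compound 4 `Cc1ccc(C(=O)Nc2cccc(C#Cc3cccc4[nH]nc(N)c34)c2)cc1C(F)(F)F` differs from compound 1 by one change: methyl in place of hydrogen on an aromatic carbon. This is methyl in place of hydrogen on an aromatic carbon, ortho to a trifluoromethyl group and para to a large group.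

Two measured steps add a group to the ring bearing the trifluoromethyl group. Fluoro gives a 1.4-fold higher number from compound 1 to compound 3 (0.14 log units; within the scatter), whereas trifluoromethyl gives an at least 6.4-fold higher number from compound 1 to compound 2 (0.81 log units; beyond the scatter), a step that ends at a limit. Neither group sits para to a large group, so both are only loose guides. In this assay, no change beyond the scatter is expected, though the second step leaves some risk of a larger loss. The expected step is a 1.3-fold higher number from compound 1 to compound 4 (0.11 log units; within the scatter). Compound 4 is estimated at 2000 nM, with an expected range of 700 nM to 7000 nM.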

Compound 4, concentration for 50% growth inhibition: 2350 nM
For compound 4 the middle estimate is 1.2-fold (0.07 log units) below the measured one; low and high end bracket the measured number.
By their numbers in this assay, from the lowest: compounds 1, 3 and 4 (each within the scatter of the next). At a limit, above all of these: compound 2.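

In this assay, methyl on the aromatic carbon ortho to a trifluoromethyl group and para to a large group gives no shift beyond the scatter: a 1.5-fold higher number from compound 1 to compound 4 (0.18 log units; within the scatter). Neither earlier added group sits para to a large group, so this is the only direct reading at this position among the compounds shown. It shows that this position accepts one added carbon on the ring bearing the trifluoromethyl group without a measurable loss of growth inhibition.

From the compounds shown here alone, whether an amine, a hydroxyl or a longer chain such as ethyl at this position would also stay within the scatter of compound 1 remains open. Compound 2 stands at a limit of the assay, so the full size of its step stays unread: the limit of > 10000 nM in this assay, at which 1 of the 4 values shown sits.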